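A few compounds are considered here, and "the series" means these few. Any claim that something is new, unique, unknown or untested is made for them only; others in the source may bear on it.

In a functional assay for inhibition, with Homo sapiens as the target (a lower number here means a stronger inhibitor, a higher number a weaker inhibitor), compound 1 `c1ccc(Nc2nccc(-c3ccco3)n2)cc1` gives 32000 nM, and compound 2 `CCN(CC)c1ccc(Nc2nccc(-c3ccco3)n2)cc1` gives 8700 nM. For compound 3 `CCN(CC)c1ccc(Nc2nccc(-c3cc(C)oc3C)n2)cc1` this assay reports only a limit, > 24000 nM, which is the limit of > 24000 nM in this assay, at which 1 of the 3 values shown sits. The step of a 3.7-fold higher number from compound 2 to compound 1 (0.57 log units; beyond the scatter) follows the change (hydrogen in place of diethylamino on an aromatic carbon). The cores of compound 2 and compound 3 differ by 2,5-dimethylfuran-3-yl in place of furan-2-yl on an aromatic carbon, and that change gave the step of an at least 2.7-fold higher number from compound 2 to compound 3 (0.44 log units; beyond the scatter). Compound 4 `Cc1cc(-c2ccnc(Nc3ccccc3)n2)c(C)o1` has not been measured in this assay; it differs from compound 3 by hydrogen in place of diethylamino on an aromatic carbon, the same change, at the same place, as that from compound 2 to compound 1. Compound 4 is expected to show the step that the limit leaves unreadable from compound 3 to compound 4 because the same change gave a 3.7-fold higher number from compound 2 to compound 1 (0.57 log units; beyond the scatter). Compound 4 is therefore estimated at 80000 nM, between 24000 nM and 300000 nM, and most probably this assay will again report only a limit for it.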

Compound 4, half-maximal inhibitory concentration: 2000 nM
Estimate against measurement, compound 4: 40-fold (1.60 log units) above; measured number outside the range, below it.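

In this assay, hydrogen in place of diethylamino gave an at least 12-fold lower number from compound 3 to compound 4 (1.07 log units; beyond the scatter), so the change did not carry over from one core to the other in this series, and its direction was reversed: the same change on two cores in this assay, a 3.7-fold higher number (0.57 log units; beyond the scatter) from compound 2 to compound 1 and an at least 12-fold lower number (1.07 log units; beyond the scatter) from compound 3 to compound 4, at least 44-fold (1.64 log units) apart, beyond the scatter of two such steps

Compound 3 stands at > 24000 nM, which is a limit of the assay and not a number. The two pairs show that the outcome of this change depends on the core among the compounds shown, but they do not show why the steps differ or how the change would run on any further core.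

As far as these compounds go, whether dimethylamino or a carboxylic acid in place of diethylamino would follow either step stays open. So does what furan-3-yl would give in place of 2,5-dimethylfuran-3-yl.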